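This account rests on a few compounds, and the source may have more. Where it says the series, first, only, none or still open, it means among the compounds named here.

Working notes on the series, read in an ADME assay on the whole organism (blood, Mus musculus, strain C57BL/6) for pharmacokinetics, read by HPLC, with a stated time of 4 h, at a dose of 2 mg/kg by the intraperitoneal route; on this read-out higher numbers stand for higher exposure at the dose given and lower numbers for lower exposure. Here compound 1 (`CN1CCN(S(=O)(=O)c2c(Cl)ccc(NC(=O)Nc3cccc(Cl)c3Cl)c2O)CC1`) gives 303 ng.h/mL, compound 2 (`CC(C)S(=O)(=O)c1c(Cl)ccc(NC(=O)Nc2cccc(F)c2Cl)c1O`) gives 198 ng.h/mL and compound 3 (`C[C@@H]1CN(S(=O)(=O)c2c(Cl)ccc(NC(=O)Nc3cccc(Cl)c3Cl)c2O)C[C@H](C)O1`) gives 519 ng.h/mL. Compound 2 lies within the scatter of compound 1 and beyond the scatter under compound 3. Compound 4 (`CCN1CCN(S(=O)(=O)c2c(Cl)ccc(NC(=O)Nc3cccc(F)c3Cl)c2O)CC1`) departs from compound 2 at one place: 4-ethylpiperazin-1-yl in place of isopropyl on a sulfonyl sulfur. For the measured compounds named here, the only measured step on a sulfonyl sulfur, a 1.7-fold higher number from compound 1 to compound 3 (0.23 log units; within the scatter), exchanges one ring for another and stays within the scatter. Going by the values given here, no measured step replaces isopropyl, so the size of this change is poorly constrained, and no shift beyond the scatter is expected in this assay. The expected step is a 1.3-fold higher number from compound 2 to compound 4 (0.12 log units; within the scatter). The estimate for compound 4 is 260 ng.h/mL, with an expected range from 110 ng.h/mL to 600 ng.h/mL.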

Compound 4, area under the concentration-time curve: 189 ng.h/mL
Compound 4: middle estimate off by 1.4-fold (0.14 log units), on the high side, and the stated range covers the measured number.
By their numbers in this assay, from the lowest: compounds 4, 2, 1 and 3 (each within the scatter of the next, the first and the last beyond it).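

On a sulfonyl sulfur, 4-ethylpiperazin-1-yl in place of isopropyl gives a 1.0-fold lower number from compound 2 to compound 4 (0.02 log units; within the scatter) in this assay and so shows no change in exposure on going from a group without a ring to one with a six-membered non-aromatic ring. The earlier step at this place only exchanged one ring for another. No measurement on these compounds offers an explanation for this result. Still open, as far as these compounds go, is whether a carboxylic acid or a longer alkyl chain on the sulfonyl sulfur would also stay within the scatter of compound 2.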